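A Hydroxymethyl Enters the Phenyl Ring of Compound 3

The source may report more compounds than this note shows. Statements on the series, on what has been measured and on what is new or still open speak of the compounds shown alone.

Compound 3 `CCCCCc1c(C(C)C)nc(C(C)C)c(CO)c1-c1cccc(C)c1` gives 46% in an assay on CHO cells for inhibition of Glucagon receptor (Homo sapiens), tested at 20 uM (on this read-out lower numbers stand for less inhibition and higher numbers for more inhibition at the one concentration tested (going by the name of the read-out)), the highest of the three numbers recorded. Compound 2 `CCCCCc1c(C(C)C)nc(C(C)C)c(CO)c1-c1ccc(CC)cc1` gives 42%, and the step of a number 4 percentage points higher from compound 2 to compound 3 (within the scatter) lies within the scatter. Compound 1 `CCCCCc1c(C(C)C)nc(C(C)C)c(CO)c1-c1ccccc1NC(C)=O` gives 13%, well below compound 3. Compound 4 `CCCCCc1c(C(C)C)nc(C(C)C)c(CO)c1-c1ccccc1CO` differs from compound 3 by 2-(hydroxymethyl)phenyl in place of 3-methylphenyl on an aromatic carbon. Going by the values given here, no measured step covers this kind of change; the only measured step, a number 4 percentage points higher from compound 2 to compound 3 (within the scatter), concerns a different replacement and was small. A drop beyond the scatter is nevertheless expected for compound 4, a number 24 percentage points lower from compound 3 to compound 4 (beyond the scatter), because compound 1 gives 13%. Compound 4 is therefore estimated at 22%, with a range from 5% to 40%.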

Compound 4, a percentage reported as inhibition, at one concentration (the size of the read-out at that concentration, not a potency): 44%
Compound 4: the middle estimate sits 22 percentage points below what was measured, outside the stated range (above it).
By their numbers in this assay, from the lowest: compound 1; then compounds 2, 4 and 3 (each within the scatter of the next).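

In this assay, the swap at this aromatic carbon leaves the number within the scatter, a number 2 percentage points lower from compound 3 to compound 4 (within the scatter), and the comparison with the 4-ethylphenyl compound is a number 2 percentage points higher from compound 2 to compound 4 (within the scatter). The large step, a number 31 percentage points higher from compound 1 to compound 4 (beyond the scatter), shows that the low number of compound 1 goes with acetamido and not with every group on that phenyl carbon. Nothing available gives a reason for these numbers. On these data alone, whether an amine or a carboxylic acid in place of hydroxymethyl would hold the number stays open. So does the effect of a longer chain, such as hydroxyethyl, there.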